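The compounds below may be only part of what the source reports. "The series", "measured", "known", "first", "only" and "open" are said of these compounds alone.

Compound 1 `C[C@]1(O)C[C@@H](OC(=O)/C=C/c2ccccc2)[C@@H]2C=CO[C@@H](O[C@@H]3O[C@H](CO)[C@@H](O)[C@H](O)[C@H]3O)[C@@H]21` opens the account. In a functional assay on BGC-823 cells (Homo sapiens) for cytotoxicity, read by MTT assay, with a stated time of 4 days (a higher number here means a weaker inhibitor, a lower number a stronger inhibitor), compound 1 gives > 10000 nM, which is a limit of the assay rather than a number. Compound 2 `COc1cc(C(=O)O[C@@H]2C[C@](C)(O)[C@H]3[C@H](O[C@@H]4O[C@H](CO)[C@@H](O)[C@H](O)[C@H]4O)OC=C[C@H]32)cc(OC)c1O[C@@H]1O[C@@H](C)[C@H](O)[C@@H](O)[C@H]1O` gives > 10000 nM in this assay, again only a limit. Compound 1 therefore stands at the limit of > 10000 nM in this assay, at which 2 of the 2 values shown sit, with no measurable value to place it. Compound 3 `C[C@]1(O)C[C@@H](OC(=O)CCc2cc(O)ccn2)[C@@H]2C=CO[C@@H](O[C@@H]3O[C@H](CO)[C@@H](O)[C@H](O)[C@H]3O)[C@@H]21` differs from compound 1 in one place: 2-(4-hydroxypyridin-2-yl)ethyl in place of 2-phenylethenyl on a carbonyl carbon. Within the data shown here, no step between measured compounds is available to show a direction, so a step that the limit leaves unreadable from compound 1 to compound 3 is expected to stay within the usual scatter. Compound 3 is expected to give 20000 nM, between 7000 nM and 100000 nM, most likely again only a limit.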

Compound 3, half-maximal inhibitory concentration: > 10000 nM
Compound 3 ended at the assay's limit; the forecaster's own chance of this, stated with the estimate: 85%; the middle value lies beyond the limit too.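

Among these compounds, no step from compound 1 to compound 3 can be read, as both ended at a limit of the assay: the limit of > 10000 nM in this assay, at which 3 of the 3 values shown sit. The compounds shown leave open how strongly any of them acts, and whether 2-(4-hydroxypyridin-2-yl)ethyl in place of 2-phenylethenyl changes that.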